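The source may report more compounds than this note shows. Statements on the series, on what has been measured and on what is new or still open speak of the compounds shown alone.

Measured so far:
compound 1 `O=C(Nc1ccc(Oc2ccnc3[nH]ccc23)cc1)c1cc2cccnc2n(-c2ccccc2)c1=O` — 1580 nM
compound 2 `O=C(Nc1ccc(Oc2ccnc3[nH]ccc23)c(F)c1)c1cc2cccnc2n(-c2ccccc2)c1=O` — 1260 nM
compound 3 `Cn1ccc2c(Oc3ccc(NC(=O)c4cc5cccnc5n(-c5ccccc5)c4=O)cc3)ccnc21` — 5030 nM

The three compounds were run in a functional assay on U-87MG ATCC cells for antiproliferative activity against U-87 MG (Homo sapiens), read by MTT assay, with a stated time of 72 h; a higher number here means a weaker inhibitor, a lower number a stronger inhibitor. Compound 2 differs from compound 1 by fluoro in place of hydrogen on an aromatic carbon; the step is a 1.3-fold lower number from compound 1 to compound 2 (0.10 log units; within the scatter). Compound 3 differs from compound 1 in the core by methyl in place of hydrogen on an aromatic nitrogen, with a 3.2-fold higher number from compound 1 to compound 3 (0.50 log units; beyond the scatter).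

Compound 4 `Cn1ccc2c(Oc3ccc(NC(=O)c4cc5cccnc5n(-c5ccc(F)cc5)c4=O)cc3)ccnc21` is not yet measured. It differs from compound 3 by fluoro in place of hydrogen on an aromatic carbon. Among the compounds with values here, this is the same kind of change as the one from compound 1 to compound 2, not the same: there the fluoro enters ortho to a large group and meta to a large group, here para to a large group, and on the phenyl rather than the other ring.

The expected step, a 1.2-fold lower number from compound 3 to compound 4 (0.08 log units; within the scatter), rests on a 1.3-fold lower number from compound 1 to compound 2 (0.10 log units; within the scatter) in this assay, which stayed within scatter. Compound 4 is therefore estimated at 4200 nM, with a range of 2000 nM to 9000 nM.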

Compound 4, half-maximal inhibitory concentration: 2120 nM
The estimate for compound 4 lay 2.0-fold (0.30 log units) above the measured number, and the stated range covers the measured number.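

Phenyl to 4-fluorophenyl gives a 2.4-fold lower number from compound 3 to compound 4 (0.38 log units; beyond the scatter) in this assay. Set beside the earlier fluoro step, the two cores cannot be told apart: the same change on two cores in this assay, a 1.3-fold lower number (0.10 log units; within the scatter) from compound 1 to compound 2 and a 2.4-fold lower number (0.38 log units; beyond the scatter) from compound 3 to compound 4, 1.9-fold (0.28 log units) apart, within the scatter of two such steps. Within the data shown here, this shows no sign that the core changes the size of the step, but it does not show that the step carries over, since only one of the two steps lies beyond the scatter and the fluoro stands at a different place on a different ring in each pair.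

Going by these compounds, whether fluoro on the phenyl gives a step of the same size on the core of compound 1 remains open. So does whether chloro, methoxy or an amine in place of that fluoro would follow it.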